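Nitrophenyl analogue in the biaryl amide series

The source may report more compounds than this note shows. Statements on the series, on what has been measured and on what is new or still open speak of the compounds shown alone.

Three members of the shared core have been run so far: compound 1 `CCOC(=O)CCCCCOc1cccc(CN(C(=O)c2ccc(-c3cccc(N(C)C)c3)cc2)C(C)C)c1` carries a dimethylamino, compound 2 `CCOC(=O)CCCCCOc1cccc(CN(C(=O)c2ccc(-c3cccc(OCc4ccccc4)c3)cc2)C(C)C)c1` a benzyloxy, and compound 3 `CCOC(=O)CCCCCOc1cccc(CN(C(=O)c2ccc(-c3cc(F)cc(OC)c3)cc2)C(C)C)c1` a 3-fluoro-5-methoxyphenyl. In an ADME assay on HepG2 cells (Homo sapiens) for cytotoxicity, read by CellTiter-Glo and resazurin assay, with a stated time of 72 h (on this read-out lower numbers stand for an effect already at smaller amounts and higher numbers for an effect only at larger amounts of compound), compound 1 reaches only the limit > 26000 nM. Compound 2 likewise reaches only the limit > 26000 nM. Compound 3 too reaches only the limit > 26000 nM. Hence there is a step that the two limits leave unreadable from compound 1 to compound 2 and a step that the two limits leave unreadable from compound 1 to compound 3, and compound 3 stands, like the other two, at the limit of > 26000 nM in this assay, at which 3 of the 3 values shown sit. Compound 4 `CCOC(=O)CCCCCOc1cccc(CN(C(=O)c2ccc(-c3cccc([N+](=O)[O-])c3)cc2)C(C)C)c1` differs from compound 3 by 3-nitrophenyl in place of 3-fluoro-5-methoxyphenyl on an aromatic carbon. Going by the values given here, no measured step bears readably on this change, so no shift beyond the scatter is expected, a step that the limit leaves unreadable from compound 3 to compound 4. Compound 4 is therefore estimated at 40000 nM, within 15000 nM to 120000 nM.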

Compound 4, half-maximal effective concentration: > 26000 nM
Compound 4 ended at the assay's limit; the forecaster's own chance of this, stated with the estimate: 85%; the middle value is on the limit's open side.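

Steps linking compound 4 with compound 1, compound 2 and compound 3 cannot be read, because all four stand at a limit: the limit of > 26000 nM in this assay, at which 4 of the 4 values shown sit.

The compounds shown leave open whether any of these groups shifts the read-out in this assay.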